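A few compounds are considered here, and "the series" means these few. Any claim that something is new, unique, unknown or untested is made for them only; others in the source may bear on it.

Measured in a functional assay on HepG2 cells (Homo sapiens) for antiproliferative activity, read by MTT assay, with a stated time of 24 h; a higher number here means a weaker inhibitor, a lower number a stronger inhibitor:
- compound 1 `CCN(CC)c1ccc(/C=C/C(=O)c2ccc(OC)c3c2OC(C)(C)C=C3)cc1`: 590 nM
- compound 2 `COc1ccc(C(=O)/C=C/c2cccc(Cl)c2)c2c1C=CC(C)(C)O2`: > 10000 nM (a limit, not a number)
- compound 3 `COc1ccccc1/C=C/C(=O)c1ccc(OC)c2c1OC(C)(C)C=C2`: > 10000 nM (a limit, not a number)

Compound 3 has no exact place on this scale. It rests at the limit of > 10000 nM in this assay, at which 2 of the 3 values shown sit. Among the measured compounds shown here, compound 2 shares that limit, so the one measured step, a step that the two limits leave unreadable from compound 2 to compound 3, gives no size to carry forward. Only compound 1 gives a true number, 590 nM.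

Compound 4 `COc1ccc(C(=O)/C=C/c2ccc(O)cc2)c2c1C=CC(C)(C)O2` has 4-hydroxyphenyl in place of 2-methoxyphenyl on a double-bonded chain carbon bound to a double-bonded chain carbon.

No readable step bears on this change, so no clear step is expected in this assay, and a reading reported only as a limit would be no surprise. This expectation rests on compound 3, whose limit is > 10000 nM. The expected size of the change is an at least 1.1-fold lower number from compound 3 to compound 4 (0.04 log units; that floor lies within the scatter). Compound 4 is estimated at 9000 nM, with an expected range from 3000 nM to 30000 nM.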

Compound 4, half-maximal inhibitory concentration: > 10000 nM
Compound 4: a limit, no number (the forecaster's own chance of this, stated with the estimate: 60%); at least 1.1-fold (0.04 log units) between middle value and limit.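

In this assay compound 4 gives > 10000 nM, which is a limit and not a number. Among the compounds shown here, its steps from compound 2 and compound 3 cannot be read, but hydroxy in place of diethylamino on an aromatic carbon gives an at least 16-fold higher number from compound 1 to compound 4 (1.22 log units; beyond the scatter), the first step in this set with a readable size. With 4-hydroxyphenyl joining 3-chlorophenyl and 2-methoxyphenyl at the limit, compound 1 remains the only compound with a true number: the limit of > 10000 nM in this assay, at which 3 of the 4 values shown sit.

Whether the activity of compound 1 needs diethylamino itself stays open: hydroxy is the only other group shown on that aromatic carbon. Another amine there, such as dimethylamino or a plain amino group, would show whether a smaller amine keeps a measurable value.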